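The source may hold more compounds than are shown below. What is called first, only, known or untested is meant among the compounds shown, and "the series" means these compounds.

Measured compounds:
compound 1 `CCCSc1nc(Cl)c2c(n1)N(Cc1ccccc1)C(C(=O)N1CCN(Cc3ccccc3)CC1)N2`, 48200 nM
compound 2 `CCCSc1nc(Cl)c2c(n1)N(Cc1cccs1)C(C(=O)N1CCN(C)CC1)N2`, 39400 nM

In a functional assay on TE-1 cells (Homo sapiens) for antiproliferative activity, read by MTT assay, with a stated time of 72 h (a higher number here means a weaker inhibitor, a lower number a stronger inhibitor), compound 1 gives 48200 nM and compound 2 gives 39400 nM; the two numbers lie within the scatter of each other, so compound 2 is not set apart from compound 1 on what has been measured. Compound 3 `CCCSc1nc(Cl)c2c(n1)N(CCNC(=O)OC(C)(C)C)C(C(=O)N1CCN(C)CC1)N2` differs from compound 2 by ((tert-butoxycarbonyl)amino)methyl in place of thiophen-2-yl on a saturated chain carbon bound to a nitrogen on an aromatic ring in a ring. Within the data shown here, no step between measured compounds covers this change, and both measured values are weak. Compound 3 is therefore expected to stay near compound 2, with the step of a 1.1-fold higher number from compound 2 to compound 3 (0.06 log units; within the scatter) expected to fall within the scatter. Compound 3 is estimated at 45000 nM in this assay, in a range from 15000 nM to 150000 nM.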

Compound 3, half-maximal inhibitory concentration: 51800 nM
Beside the measured number, compound 3's estimate is 1.2-fold (0.06 log units) below it; the range from low to high includes it.
By their numbers in this assay, from the lowest: compounds 2, 1 and 3 (each within the scatter of the next).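

In this assay, ((tert-butoxycarbonyl)amino)methyl in place of thiophen-2-yl on a saturated chain carbon bound to a nitrogen on an aromatic ring in a ring gives a 1.3-fold higher number from compound 2 to compound 3 (0.12 log units; within the scatter). At this place, then, a group with no ring and with a hydrogen-bond donor stands in for a five-membered aromatic ring with no difference beyond the scatter. No further data bear on this result. Still open, going by these compounds, is whether a free primary amine, a carboxylic acid or a longer chain here would move the number beyond the scatter.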